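The source may report more compounds than this note shows. Statements on the series, on what has been measured and on what is new or still open speak of the compounds shown alone.

In a functional assay on PC-3 cells (Homo sapiens) for cytotoxicity, read by colorimetric assay and MTT assay (a lower number here means a stronger inhibitor, a higher number a weaker inhibitor), compound 1 (`COc1cccc2cc(-c3ccccc3)c(O)nc12`) gives 10000 nM and compound 2 (`COc1ccc(-c2cc3c(OC)ccc(OC)c3nc2O)cc1`) gives 10000 nM while compound 3 (`CCN(CC)C(=O)Cn1c(=O)c(-c2ccc(OC)cc2)cc2c(OC)cc(OC)cc21`) gives 10000 nM as well, so compound 3 stands level with both, within the usual scatter of repeat measurements. Compound 4 (`COc1ccc(-c2cc3c(OC)cc(OC)cc3n(CC(=O)OCc3ccccc3)c2=O)cc1`) keeps the core of compound 3 and changes one group, with benzyloxy in place of diethylamino on a carbonyl carbon. Going by the values given here, no measured pair yet shows what such a swap does. With compound 3 at 10000 nM and no spread among the three tested compounds, no step beyond the scatter is expected in either direction. The estimated step (a 1.1-fold lower number from compound 3 to compound 4 (0.05 log units; within the scatter)) is therefore small. For compound 4 the expected value is 9000 nM with an estimated range from 3000 nM to 20000 nM as its likely span.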

Compound 4, half-maximal inhibitory concentration: 10000 nM
Compound 4: middle estimate off by 1.1-fold (0.05 log units), on the low side; the range from low to high includes it.
By their numbers in this assay, from the lowest: compounds 1, 2, 3 and 4 (each within the scatter of the next).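

In this assay, going by these compounds alone, putting benzyloxy in place of diethylamino on a carbonyl carbon gives no change at the digits printed from compound 3 to compound 4 (within the scatter), and this is the first measured pair that differs in one place. At this position, then, exchanging the diethylamino group for one carrying a six-membered aromatic ring leaves the number unmoved. No evidence is available that would explain this result.

As far as these compounds go, whether a carboxylic acid or a primary amide at the same carbonyl carbon would shift the number remains open. So does whether a longer chain between that carbonyl and the shared core would do so.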